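Replacing dipropylamino with a piperidine-bearing side chain

The compounds below may be only part of what the source reports. "The series", "measured", "known", "first", "only" and "open" are said of these compounds alone.

Measured compounds:
compound 1 `NS(=O)(=O)Oc1ccc2c(c1)CN(C(=O)c1cccc(N3CCCCC3)c1)CC2` — 11.9%
compound 2 `CN(C)CCN(CCN(C)C)c1cccc(C(=O)N2CCc3ccc(OS(N)(=O)=O)cc3C2)c1` — 17.1%
compound 3 `CCCN(CCC)c1cccc(C(=O)N2CCc3ccc(OS(N)(=O)=O)cc3C2)c1` — 54.8%

In an assay on HEK293 cells for inhibition of Steryl-sulfatase (Homo sapiens), tested at 1 uM (a lower number here means a weaker effect, a higher number a stronger effect of the compound at the concentration tested), compound 3 gives 54.8%, the highest of the three numbers. Compound 2 gives 17.1% and compound 1 gives 11.9%; the two steps to compound 3 are a number 42.9 percentage points higher from compound 1 to compound 3 (beyond the scatter) and a number 37.7 percentage points higher from compound 2 to compound 3 (beyond the scatter), both large and beyond the scatter, whereas a number 5.2 percentage points higher from compound 1 to compound 2 (within the scatter) is within the scatter.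

Compound 4 `CN(CCN1CCCCC1)c1cccc(C(=O)N2CCc3ccc(OS(N)(=O)=O)cc3C2)c1` has not yet been measured. It differs from compound 3 in one place: methyl(2-(piperidin-1-yl)ethyl)amino in place of dipropylamino on an aromatic carbon. Both steps that bear on this change move in the same sense: whenever dipropylamino stands on the aromatic carbon, the number is far higher than with piperidin-1-yl or with bis(2-(dimethylamino)ethyl)amino. Removing dipropylamino is therefore expected to cost a good part of the gain seen in compound 3, and the entering group, which carries a second nitrogen as compound 2 does, gives no sign in the data of restoring it. The step is expected to be a number 29.8 percentage points lower from compound 3 to compound 4 (beyond the scatter), downward and beyond the scatter. Compound 4 is thus estimated at 25%, with a range from 8% to 45%.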

Compound 4, a percentage reported as inhibition, at one concentration (the size of the read-out at that concentration, not a potency): 30.8%
For compound 4 the middle estimate is 5.8 percentage points below the measured one; measured number inside the range.
By their numbers in this assay, from the lowest: compounds 1 and 2 (each within the scatter of the next); then compound 4; then compound 3.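

In this assay, exchanging dipropylamino for methyl(2-(piperidin-1-yl)ethyl)amino gives a number 24 percentage points lower from compound 3 to compound 4 (beyond the scatter), which confirms with a group of a new kind that the number at this position falls when dipropylamino leaves. The fall is only partial, however: the entering group also gives a number 13.7 percentage points higher from compound 2 to compound 4 (beyond the scatter) and a number 18.9 percentage points higher from compound 1 to compound 4 (beyond the scatter), so the earlier split between one high compound and two low compounds becomes a graded order, and a second nitrogen in the group does not by itself bring the number down to that of compound 2. Nothing measured here accounts for these differences among the groups on the aromatic carbon.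

The compounds shown do not separate the contribution of the piperidine ring at the end of the chain from that of the methyl on the attached nitrogen, since the two enter together in compound 4. Going by these compounds, how a morpholine ring in place of that piperidine ring, or a dibutylamino group in place of dipropylamino, would stand in this assay remains open.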